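The compounds below may be only part of what the source reports. "The series", "measured", "known", "first", "only" and "open" are said of these compounds alone.

Series notes. Three compounds of the shared core have numbers. In an assay on isolated protein for inhibition of sulfide:quinone oxidoreductase, mitochondrial (Homo sapiens) (on this read-out lower numbers stand for stronger inhibition and higher numbers for weaker inhibition), compound 1 `COc1nc(-c2ccccc2)cc(-c2ccc(Cl)cc2)c1C#N` gives 252 nM. Compound 3 `COc1nc(-c2cccnc2)cc(-c2ccc(F)cc2)c1C#N` gives 213 nM in this assay. Compound 2 `N#Cc1c(-c2ccccc2)cc(-c2ccccc2)nc1OCc1ccccc1` gives 100 nM in this assay, the lowest of the three numbers; its step to compound 3 and its step to compound 1 both lie beyond the scatter, so compound 2 stands as the most potent of the measured set.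

Compound 4 `COc1nc(-c2ccccc2)cc(-c2ccccc2)c1C#N` has not been measured in this assay. It differs from compound 2 in one place: hydrogen in place of phenyl on a saturated chain carbon bound to an oxygen on an aromatic ring. Going by the values given here, no measured pair in the set is separated by this change alone, so the size of the step is not known from a direct comparison. The two methoxy compounds with numbers, compound 1 and compound 3, both fall on the weaker side of compound 2, though each of them also differs from compound 2 in its aryl substituents, so they give only a loose pointer. On that basis the expected step, a 2.0-fold higher number from compound 2 to compound 4 (0.30 log units; within the scatter), is a move toward weaker inhibition, of a size beyond the scatter. Compound 4 is estimated at 200 nM in this assay, with a range from 90 nM to 450 nM.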

Compound 4, half-maximal inhibitory concentration: 53 nM
Compound 4: middle estimate off by 3.8-fold (0.58 log units), on the high side; measured number below the stated range.
By their numbers in this assay, from the lowest: compounds 4 and 2 (each within the scatter of the next); then compounds 3 and 1 (each within the scatter of the next).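

In (this assay), cutting benzyloxy back to methoxy gives (a 1.9-fold lower number from compound 2 to compound 4 (0.28 log units; within the scatter)), so the phenyl on this saturated chain carbon can go without a shift that stands clear of the scatter, and on this read-out the two ether groups cannot be told apart. Compound 1 and compound 4 supply the first one-place step on an aryl group (a 4.8-fold lower number from compound 1 to compound 4 (0.68 log units; beyond the scatter)), and hydrogen in place of chloro on an aromatic carbon is the only single change shown here that lies beyond the scatter. No supporting data bear on either step.

As far as these compounds go, whether the saturated chain carbon bound to the oxygen tolerates anything other than hydrogen or phenyl, such as a longer chain or a chain ending in an amine, remains open. Chloro is the only group compared with hydrogen on that aromatic carbon in a one-place step, so it is open how a group such as a methoxy or a carboxylic acid would read there, and whether the chloro step would hold with benzyloxy on the core.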